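Changing the aryl group on the nitrogen

The source may hold more compounds than are shown below. What is called first, only, known or untested is meant among the compounds shown, and "the series" means these compounds.

Measured so far in a functional assay on MKN-45 cells (Homo sapiens) for antiproliferative activity (a lower number here means a stronger inhibitor, a higher number a weaker inhibitor), for two compounds
Compound 1 `COc1ccc(S(=O)(=O)N2CCc3cccc(Nc4ccccc4)c32)cc1` gives 187 nM
Compound 2 `COc1ccc(S(=O)(=O)N2CCc3cccc(Nc4ccc(F)c(F)c4)c32)cc1` gives 726 nM

Within the data shown here, compound 2 holds the higher of these two numbers, which makes it the weaker inhibitor of the pair, and compound 1 is its only neighbour. The next compound is compound 3 `COc1ccc(S(=O)(=O)N2CCc3cccc(Nc4ccc(C#N)cc4)c32)cc1` and the change from compound 2 is this: 4-cyanophenyl in place of 3,4-difluorophenyl on a nitrogen on an aromatic ring. Among the measured compounds shown here, one measured step bears on it, at the same place: a 3.9-fold higher number from compound 1 to compound 2 (0.59 log units; beyond the scatter) when 3,4-difluorophenyl replaced phenyl. That step was modest but beyond the scatter. For the measured compounds named here, no measured compound carries the 4-cyanophenyl group, so this step suggests a size more than a firm direction. Compound 1 at 187 nM shows that this place can give a lower number once the 3,4-difluorophenyl group is gone. A small move toward a lower number is therefore expected in this assay and it may not clear the scatter. The expected change is a 1.8-fold lower number from compound 2 to compound 3 (0.26 log units; within the scatter) on this reading. The estimate for compound 3 is 400 nM with an expected range from 120 nM to 1300 nM around it.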

Compound 3, half-maximal inhibitory concentration: 92 nM
The estimate for compound 3 lay 4.3-fold (0.64 log units) above the measured number; the measured number lies below the stated range.
By their numbers in this assay, from the lowest: compound 3; then compound 1; then compound 2.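

In this assay, the aryl group on the nitrogen can now be seen to move the number in both directions: 4-cyanophenyl in place of 3,4-difluorophenyl gave a 7.9-fold lower number from compound 2 to compound 3 (0.90 log units; beyond the scatter). Cyano in place of hydrogen on an aromatic carbon gave a 2.0-fold lower number from compound 1 to compound 3 (0.31 log units; beyond the scatter), a modest step beyond the scatter, so the unsubstituted phenyl group of compound 1 no longer marks the low end of the series, and a substituent on this ring does not always raise the number as the 3,4-difluorophenyl group did. The compounds come with no separate measurement that could account for the difference between these groups.

Among these compounds, with only three aryl groups at this place, it remains open whether the low number of compound 3 is particular to the nitrile or would also appear with a 4-methoxyphenyl or 4-carboxyphenyl group. It is equally unsettled whether a pyridine ring, or a saturated ring such as piperidine, could take the place of the aryl group on the nitrogen and keep the number low.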